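Swapping Cyano for Chloro at the Assay Limit

The source may hold more compounds than are shown below. What is called first, only, known or untested is meant among the compounds shown, and "the series" means these compounds.

Values in a functional assay on HT-29 cells (Homo sapiens); a lower number here means a stronger inhibitor of growth, a higher number a weaker inhibitor of growth:
Compound 1 `O=S(=O)(/C=C/c1ccccc1)Cc1ccc(Nc2ncnc3ccccc23)cc1` gives > 100000 nM (a limit).
Compound 2 `N#Cc1ccc(/C=C/S(=O)(=O)Cc2ccc(Nc3ncnc4ccccc34)cc2)cc1` gives > 100000 nM (a limit).
Compound 3 `CC(C)(C)c1cc(/C=C/S(=O)(=O)Cc2ccc(Nc3ncnc4ccccc34)cc2)cc(C(C)(C)C)c1O` gives 17000 nM.

Compound 2 gives no number in this assay, only a limit of > 100000 nM. It shares that position with compound 1, and the overall picture is the limit of > 100000 nM in this assay, at which 2 of the 3 values shown sit. Compound 3, at 17000 nM, is the only one of the three with a true number.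

The next compound to be tested is compound 4 `O=S(=O)(/C=C/c1ccc(Cl)cc1)Cc1ccc(Nc2ncnc3ccccc23)cc1`. It differs from compound 2 in one place, with chloro in place of cyano on an aromatic carbon.

Going by the values given here, only one measured step bears on this change, a step that the two limits leave unreadable from compound 1 to compound 2. It also concerns a substituent on an aromatic carbon, but with limits at both ends it has no size to carry over. Expected here is a number no higher from compound 2 to compound 4 (the limit leaves the size open), with no firm direction and no shift beyond the scatter foreseen. Compound 4 is expected to stay close to the limit and may well report only a limit itself.

For compound 4 the estimated value is 100000 nM, with an expected range from 30000 nM to 300000 nM.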

Compound 4, concentration for 50% growth inhibition: 73000 nM
Compound 4: the middle estimate sits 1.4-fold (0.14 log units) above what was measured; the measured number falls inside the stated range.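

In this assay, going by these compounds alone, compound 4 gives a true number, 73000 nM, the first measured value among the compounds that differ only in the substituent on this aromatic carbon. Chloro in place of cyano gives an at least 1.3-fold lower number from compound 2 to compound 4 (0.13 log units; that floor lies within the scatter), and chloro in place of hydrogen gives an at least 1.3-fold lower number from compound 1 to compound 4 (0.13 log units; that floor lies within the scatter). On these data alone, with a limit at one end, each of these steps is only a floor whose full size stays unknown, so neither swap can yet be said to change growth inhibition beyond the usual scatter, and the step from compound 1 to compound 2 still cannot be read.

Also open, as far as these compounds go, is what an amine, a methoxy group or a bromo group would give on the same aromatic carbon, para to a large group, in this assay. The true values of compound 1 and compound 2 remain unknown, leaving the full effect of each substituent undefined at this position: the limit of > 100000 nM in this assay, at which 2 of the 4 values shown sit.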